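A few compounds are considered here, and "the series" means these few. Any claim that something is new, unique, unknown or untested is made for them only; others in the source may bear on it.

Series note. Compound 1 `CNc1cc(Oc2ccc(NC(=O)Nc3cccc(C(F)F)c3)cc2)ncn1` carries a 3-(difluoromethyl)phenyl group on the urea. In an assay on isolated protein for inhibition of serine/threonine-protein kinase TNNI3K (Homo sapiens) (a lower number here means a stronger inhibitor, a higher number a weaker inhibitor), compound 1 gives 100 nM, the highest number among the three measured compounds. Compound 2 `Nc1cc(Oc2ccc(NC(=O)Nc3cccc(C(F)(F)F)c3)cc2)ncn1` gives 25 nM, a number that lies beyond the scatter from the value of compound 1. Compound 3 `CNc1cc(Oc2ccc(NC(=O)Nc3cccc(C(F)(F)F)c3)c(F)c2)ncn1` gives 63 nM, which sits within the scatter of compound 1, so no order between compound 1 and compound 3 can be read from these two values. For the measured compounds named here, no step between measured compounds that differ in a single place is available, and compound 2 and compound 3 each differ from compound 1 in more than one place, so their values say nothing directly about the change considered next.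

Compound 4 `CNc1cc(Oc2ccc(NC(=O)Nc3cccc(CF)c3)cc2)ncn1` has not yet been measured. It differs from compound 1 by hydrogen in place of fluoro on a saturated chain carbon bound to an aromatic carbon and a fluorine atom; in other words the difluoromethyl becomes a fluoromethyl. Going by the values given here, with no matching step in hand, the direction can only be guessed, and the working expectation for compound 4 is a small rise in the number, near the edge of the scatter, as the step of a 2.0-fold higher number from compound 1 to compound 4 (0.30 log units; within the scatter). Compound 4 is therefore estimated at 200 nM, with a range from 70 nM to 600 nM.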

Compound 4, half-maximal inhibitory concentration: 400 nM
Compound 4: the middle estimate sits 2.0-fold (0.30 log units) below what was measured; measured number inside the range.
By their numbers in this assay, from the lowest: compound 2; then compounds 3 and 1 (each within the scatter of the next); then compound 4.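

For the compounds shown here, replacing one fluoro of the difluoromethyl group with hydrogen gives the only single-place comparison so far: in this assay, the change to fluoromethyl produces a 4.0-fold higher number from compound 1 to compound 4 (0.60 log units; beyond the scatter), a modest step towards weaker inhibition. This saturated chain carbon is therefore not indifferent to the exchange of fluoro for hydrogen, at least on the core of compound 1. Nothing at hand bears on the reason for this step.

Compound 2 and compound 3 carry trifluoromethyl but differ from compound 1 in more than one place, so they cannot show whether the trend extends to a third fluoro. On these data alone, how a plain methyl, a chloro or a nitrile in place of the difluoromethyl would compare on the core of compound 1 also remains open.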